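The source may hold more compounds than are shown below. What is called first, only, known or untested is meant among the compounds shown, and "the series" means these compounds.

Three boron-containing compounds have been tested so far in an assay on HEK293 cells for inhibition of transient receptor potential cation channel subfamily V member 6 (Homo sapiens), read by FLIPR and calcium flux, with a stated time of 5 min; a lower number here means a stronger inhibitor, a higher number a weaker inhibitor. Compound 1, `c1ccc([B-]2(c3ccccc3)[NH2+]CCS2)cc1`, is the weakest of the set: in this assay compound 1 gives 127000 nM. Compound 2, `Cc1ccccc1[B-]1(c2ccccc2)[NH2+]CCO1`, carries a methyl group on one of its aromatic rings and in this assay compound 2 gives 31100 nM. Compound 3, `Cc1ccc([B-]2(c3ccccc3)[NH2+]CCO2)cc1`, places the methyl group elsewhere on that ring and in this assay compound 3 gives 18900 nM, the lowest of the three numbers; the gap to compound 2 lies within the scatter of the measurement, so nothing separates these two, while the gap to compound 1 lies well beyond it.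

Compound 4, `c1ccc(-c2ccc([B-]3(c4ccccc4)[NH2+]CCO3)cc2)cc1`, has not yet been measured. It differs from compound 3 in one place: phenyl in place of methyl on an aromatic carbon. Among the measured compounds shown here, no pair of measured compounds shows this kind of change, so the size of the step can only be guessed. Given that compound 3 already gives 18900 nM, a moderate move toward a lower number is expected, though one that may not exceed the scatter. For compound 4 the expected value in this assay is 12000 nM, with a range from 3000 nM to 40000 nM, which would mean an expected step of a 1.6-fold lower number from compound 3 to compound 4 (0.20 log units; within the scatter).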

Compound 4, half-maximal inhibitory concentration: 72300 nM
Compound 4: middle estimate off by 6.0-fold (0.78 log units), on the low side; the whole stated range lies below it.
By their numbers in this assay, from the lowest: compounds 3 and 2 (each within the scatter of the next); then compounds 4 and 1 (each within the scatter of the next).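

In this assay, phenyl in place of methyl on an aromatic carbon, para to a large group, gives a 3.8-fold higher number from compound 3 to compound 4 (0.58 log units; beyond the scatter), a step beyond the scatter and towards weaker inhibition. Among the compounds shown here, this is the first change in the set that can be read at a single place, and it shows that inhibition at this position depends on what the position carries: going from methyl, with 1 heavy atom, to phenyl, with 6 heavy atoms, weakens inhibition even though neither group has hydrogen-bond donors, hydrogen-bond acceptors or a net charge. Nothing in the data given here accounts for the direction or the size of this step.

A single step cannot show whether the loss goes with the added aromatic ring itself or with the larger number of heavy atoms, and it says nothing of how far the trend runs between these two groups. An ethyl or propyl chain, a cyclohexyl ring, or a methoxy group or an amine on the same carbon would be needed to tell these readings apart.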